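The compounds below may be only part of what the source reports. "The series", "measured", "known", "first", "only" and "open" are said of these compounds alone.

The measured compounds:
compound 1, `O=C(N/N=C/c1cccc(O)c1)c1cccnc1Nc1cccc(C(F)(F)F)c1` — in a functional assay on the whole organism (strain Wistar) for inhibition, with Rattus norvegicus as the target, read by paw edema, with a stated time of 4 h, at a dose of 10 mg/kg by the intraperitoneal route (a lower number here means less inhibition, a higher number more inhibition at the dose given (going by the name of the read-out)), compound 1 gives 35.8%.
compound 2, `COc1cccc(/C=N/NC(=O)c2cccnc2Nc2cccc(C(F)(F)F)c2)c1` — compound 2 gives 14.9%.
compound 3, `COc1ccc(/C=N/NC(=O)c2cccnc2Nc2cccc(C(F)(F)F)c2)cc1OC` — compound 3 gives 52.9%.

Compound 3 stands highest of the three. Compound 1 lies below it, a number 17.1 percentage points higher from compound 1 to compound 3 (beyond the scatter), and compound 2 lies furthest below, a number 38 percentage points higher from compound 2 to compound 3 (beyond the scatter). Within the measured set, putting a methyl on the oxygen of compound 1 lowered the read-out, a number 20.9 percentage points lower from compound 1 to compound 2 (beyond the scatter), while adding the second methoxy to compound 2 raised it strongly, a number 38 percentage points higher from compound 2 to compound 3 (beyond the scatter).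

Compound 4, `O=C(N/N=C/c1ccncc1)c1cccnc1Nc1cccc(C(F)(F)F)c1`, has not yet been measured. Its change from compound 3 is pyridin-4-yl in place of 3,4-dimethoxyphenyl on a carbon with a double bond to nitrogen. For the measured compounds named here, no measured step removes both methoxy groups at once, and none introduces a ring nitrogen on this ring, so the change has no direct counterpart. The closest evidence is the step from compound 2 to compound 3, which shows that the read-out was much lower when one methoxy was missing; compound 4 carries neither. Going by the values given here, a drop beyond the scatter is therefore expected, a number 27.9 percentage points lower from compound 3 to compound 4 (beyond the scatter), though its size is uncertain since the pyridin-4-yl has no measured analogue here. Compound 4 is estimated at 25%, within 5% to 45%.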

Compound 4, a percentage reported as inhibition, in the whole organism at one dose (the size of the read-out at that dose, not a potency): 45.9%
Beside the measured number, compound 4's estimate is 20.9 percentage points below it, outside the stated range (above it).
By their numbers in this assay, from the lowest: compound 2; then compound 1; then compounds 4 and 3 (each within the scatter of the next).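

In this assay, pyridin-4-yl on the carbon with a double bond to nitrogen gives a read-out that cannot be told apart from that of the 3,4-dimethoxyphenyl group, a number 7 percentage points lower from compound 3 to compound 4 (within the scatter), so a ring with neither methoxy group and with a ring nitrogen instead can hold this level. The same group also stands clear of the 3-methoxyphenyl and 3-hydroxyphenyl groups, a number 31 percentage points higher from compound 2 to compound 4 (beyond the scatter) and a number 10.1 percentage points higher from compound 1 to compound 4 (beyond the scatter), which shows that the read-out at this position does not simply follow the number of methoxy groups on a phenyl ring. Nothing measured here bears on why these groups differ as they do.

The compounds shown leave open what a plain phenyl group would give at this place, a comparison that would separate the ring nitrogen from the absence of the methoxy groups, and whether pyridin-3-yl or pyridin-2-yl would match pyridin-4-yl. Also open, going by these compounds, is how an amine or a carboxylic acid on this ring would fare, and whether the same ranking would hold at other doses or times.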